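This account rests on a few compounds, and the source may have more. Where it says the series, first, only, none or still open, it means among the compounds named here.

Among the compounds with values here, compound 2 `O=C(Nc1ccc(-n2ncc3c(F)cccc32)cc1)Nc1ccc(Cl)c(C(F)(F)F)c1` gives 32000 nM in a functional assay on SGC-7901 cells (Homo sapiens) for cytotoxicity, read by MTT assay, with a stated time of 72 h (on this read-out lower numbers stand for stronger inhibition and higher numbers for weaker inhibition), the highest of the two numbers measured so far. Within the data shown here, its closest neighbour, compound 1 `O=C(Nc1ccc(-n2ncc3c(Cl)cccc32)cc1)Nc1ccc(Cl)c(C(F)(F)F)c1`, gives 4600 nM in this assay; the step of a 7.0-fold higher number from compound 1 to compound 2 (0.84 log units; beyond the scatter) is the only change measured at this position of the shared core, and it shows that a one-atom exchange there moves the number well beyond the scatter. Compound 3 `Cc1cccc2c1cnn2-c1ccc(NC(=O)Nc2ccc(Cl)c(C(F)(F)F)c2)cc1` is the next variation at the same position: methyl in place of fluoro on an aromatic carbon. Among the measured compounds shown here, only the step from compound 1 to compound 2 bears on it, and its size, modest but clear, sets the scale of what a single exchange at this carbon can do. For the measured compounds named here, since no step with methyl itself is known, a move back toward the reading of compound 1 is expected but not assured. Compound 3 is therefore expected to give 10000 nM in this assay, with a range from 3000 nM to 35000 nM. That estimate corresponds to an expected step of a 3.2-fold lower number from compound 2 to compound 3 (0.51 log units; beyond the scatter).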

Compound 3, half-maximal inhibitory concentration: 14200 nM
Compound 3: middle estimate off by 1.4-fold (0.15 log units), on the low side; the range from low to high includes it.
By their numbers in this assay, from the lowest: compound 1; then compound 3; then compound 2.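

Replacing fluoro with methyl at this aromatic carbon gives a 2.3-fold lower number from compound 2 to compound 3 (0.35 log units; beyond the scatter) in this assay, while replacing chloro with methyl gives a 3.1-fold higher number from compound 1 to compound 3 (0.49 log units; beyond the scatter), so the effect of a single exchange here is no longer shown by one pair alone. The three groups now form an order at this carbon, from the lowest number: chloro in compound 1, methyl in compound 3, then fluoro in compound 2. No measurement at hand gives a reason for that order.

The three compounds leave open how bromo, methoxy or an amine at this carbon would compare with chloro, and whether any of them would give a lower number than compound 1 does. They also leave open whether the same order would hold if the rest of the shared core were changed.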